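Furanyl in Place of Iodo on a Nucleoside Core

A few compounds are considered here, and "the series" means these few. Any claim that something is new, unique, unknown or untested is made for them only; others in the source may bear on it.

Compound 1 `Nc1nc(N)c2c(-c3ccsc3)cn([C@@H]3O[C@H](CO)[C@@H](O)[C@H]3O)c2n1`: > 100000 nM
Compound 2 `O=c1[nH]cnc2c1c(-c1ccoc1)cn2[C@@H]1O[C@H](CO)[C@@H](O)[C@H]1O`: > 100000 nM
Compound 3 `Cc1ncnc2c1c(I)cn2[C@@H]1O[C@H](CO)[C@@H](O)[C@H]1O`: 13300 nM

Among the compounds with values here, in an ADME assay on MRC5 cells (Homo sapiens), read by MTT assay, with a stated time of 72 h (on this read-out higher numbers stand for weaker inhibition and lower numbers for stronger inhibition), compound 3 gives 13300 nM, the only actual number among the three. For compound 1 the value > 100000 nM is a limit of the assay, not a number. For compound 2 the value > 100000 nM is likewise a limit. Compound 4 `Cc1ncnc2c1c(-c1ccoc1)cn2[C@@H]1O[C@H](CO)[C@@H](O)[C@H]1O` has not yet been measured; it differs from compound 3 by furan-3-yl in place of iodo on an aromatic carbon. Within the data shown here, no step between measured compounds exists here, so the expectation rests on (the limit of > 100000 nM in this assay, at which 2 of the 3 values shown sit), where both compounds carrying a five-membered aromatic ring sit. The step from compound 3 to compound 4 is expected to move the value toward weaker inhibition, beyond the scatter, by a 4.5-fold higher number from compound 3 to compound 4 (0.65 log units; beyond the scatter). Compound 4 is therefore estimated at 60000 nM, within 15000 nM to 150000 nM.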

Compound 4, half-maximal inhibitory concentration: 98300 nM
Estimate against measurement, compound 4: 1.6-fold (0.21 log units) below, within the range that was stated.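

In this assay, putting furan-3-yl in place of iodo on this aromatic carbon gives a 7.4-fold higher number from compound 3 to compound 4 (0.87 log units; beyond the scatter), so inhibition at this position depends on the group it carries. Compound 4 gives 98300 nM, an actual number that lies close to the top of what the assay reports: the limit of > 100000 nM in this assay, at which 2 of the 4 values shown sit.

One pair cannot separate the effect of losing iodo from that of adding the furan ring. On these data alone, how an amine, a carboxylic acid or a longer chain would behave on this carbon remains open.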